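Swapping the basic ring on the chain of a weak inhibitor

The source may hold more compounds than are shown below. What is called first, only, known or untested is meant among the compounds shown, and "the series" means these compounds.

Compound 1 `CCCCOc1ccc2c(c1)/C(=N/N1CC(=O)N(CCCCN3CCN(C)CC3)C1=O)CCO2` is the starting point: in an assay on cells (Ventricular myocyte) for inhibition of potassium voltage-gated channel subfamily KQT member 1 (Cavia porcellus), read by patch clamp (a higher number here means a weaker inhibitor, a lower number a stronger inhibitor), compound 1 gives 22 nM. Compound 2 `CN1CCN(CCCCN2C(=O)CN(/N=C3\CCOc4ccc(O)cc43)C2=O)CC1` keeps the whole framework but carries a hydrogen in place of the butyl on the aromatic oxygen, and in this assay compound 2 gives 60000 nM. For the measured compounds named here, that single change makes the step of a 2700-fold higher number from compound 1 to compound 2 (3.44 log units; beyond the scatter), so compound 2 stands at the highest of the two numbers measured so far, far from compound 1.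

Compound 3 `O=C1CN(/N=C2\CCOc3ccc(O)cc32)C(=O)N1CCCCN1CCCCC1` is not yet measured. Compared with compound 2 it differs in one place: piperidin-1-yl in place of 4-methylpiperazin-1-yl on a saturated chain carbon, four bonds along the chain from an amide-type nitrogen in a ring. Going by the values given here, the only measured step concerns the aromatic oxygen, on the opposite side of the shared core, and says nothing about the amine at the end of the chain. No measured comparison bears on this change, so there is no basis for expecting a step beyond the usual scatter in either direction. Compound 3 is therefore expected to sit close to compound 2, at about 45000 nM, within a range of 12000 nM to 170000 nM, which corresponds to an estimated step of a 1.3-fold lower number from compound 2 to compound 3 (0.12 log units; within the scatter).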

Compound 3, half-maximal inhibitory concentration: 5400 nM
For compound 3 the middle estimate is 8.3-fold (0.92 log units) above the measured one; measured number outside the range, below it.
By their numbers in this assay, from the lowest: compound 1; then compound 3; then compound 2.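

For the compounds shown here, the far end of the chain is no silent spot: in this assay, piperidin-1-yl in place of 4-methylpiperazin-1-yl gives an 11-fold lower number from compound 2 to compound 3 (1.05 log units; beyond the scatter), so this position, which no earlier pair had touched, can shift the number by a large step on its own. The change looks small on paper, going from 7 heavy atoms to 6, from 2 nitrogen atoms to 1 and from 2 hydrogen-bond acceptors to 1, yet compound 3 is the stronger inhibitor of this pair. Nothing in the data at hand explains the size of this step.

Going by these compounds alone, it remains open whether the same swap would have a similar effect with a butyl group on the aromatic oxygen, as in compound 1, given that the only step at that oxygen has 4-methylpiperazin-1-yl on the chain. Also open, going by these compounds, is how other amines at the chain end, such as morpholin-4-yl, pyrrolidin-1-yl or an open-chain diethylamino group, would compare with piperidin-1-yl, and whether a shorter or longer chain would change the picture.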